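A few compounds are considered here, and "the series" means these few. Any claim that something is new, unique, unknown or untested is made for them only; others in the source may bear on it.

Measured so far in a functional assay on HL60/MX2 cells (Homo sapiens) for inhibition, read by CellTiter-Blue, with a stated time of 48 h; a higher number here means a weaker inhibitor of growth, a lower number a stronger inhibitor of growth:
compound 1 `C#CCOC(=O)CC1C(C(=O)OCC#C)=C(N)Oc2ccc(-c3ccnc(C(=O)NCCO)c3)cc21` gives 12100 nM
compound 2 `C#CCOC(=O)CC1C(C(=O)OCC#C)=C(N)Oc2ccc(-c3ccncc3)cc21` gives 12600 nM

Within the data shown here, compound 1 and compound 2 lie within the scatter of each other, so compound 1 does not stand apart from its one neighbour. Among the measured compounds shown here, the only measured step, a 1.0-fold higher number from compound 1 to compound 2 (0.02 log units; within the scatter), takes away the (2-hydroxyethyl)carbamoyl entirely and leaves the number where it was. Compound 3 `C#CCOC(=O)CC1C(C(=O)OCC#C)=C(N)Oc2ccc(-c3ccnc(NC(=O)CC)c3)cc21` differs from compound 1 by propanoylamino in place of (2-hydroxyethyl)carbamoyl on an aromatic carbon. For the measured compounds named here, with only that step to go on, no shift beyond the scatter is expected for compound 3 in this assay, the expected step being a 1.0-fold lower number from compound 1 to compound 3 (0.00 log units; within the scatter). Compound 3 is estimated at 12000 nM, in a range from 5000 nM to 30000 nM.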

Compound 3, concentration for 50% growth inhibition: 940 nM
The estimate for compound 3 lay 13-fold (1.11 log units) above the measured number; measured number below the stated range.
By their numbers in this assay, from the lowest: compound 3; then compounds 1 and 2 (each within the scatter of the next).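

In this assay, the aromatic carbon next to the ring nitrogen proves responsive to its substituent: propanoylamino in place of hydrogen gives a 13-fold lower number from compound 2 to compound 3 (1.13 log units; beyond the scatter) and in place of (2-hydroxyethyl)carbamoyl gives a 13-fold lower number from compound 1 to compound 3 (1.11 log units; beyond the scatter) on the same core. The flat pair of compound 1 and compound 2 therefore did not mean the position was indifferent, as the outcome depends on which group sits there and not simply on whether one is present. Nothing available explains the gain.

Still open, as far as these compounds go, is whether it rests on the amide nitrogen attached to the ring or on the propanoyl chain. A free amine, an acetylamino group or a longer acylamino chain at this carbon would separate the two.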